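From bromophenyl to hydroxyphenyl: an untested step

The source may hold more compounds than are shown below. What is called first, only, known or untested is meant among the compounds shown, and "the series" means these compounds.

compound 1: `COc1ccc(C(=O)/C=C/c2ccc(Br)cc2)c2c1C=CC(C)(C)O2` — > 10000 nM
compound 2: `COc1ccc(C(=O)/C=C/c2ccc(OC)c(OC)c2OC)c2c1C=CC(C)(C)O2` — > 10000 nM
compound 3: `COc1ccc(C(=O)/C=C/c2cccc(O)c2)c2c1C=CC(C)(C)O2` — not yet measured

In a functional assay on SK-OV-3 cells (Homo sapiens) for antiproliferative activity, read by MTT assay, with a stated time of 24 h (on this read-out higher numbers stand for weaker inhibition and lower numbers for stronger inhibition), compound 1 gives > 10000 nM, which is a limit of the assay rather than a number. Compound 2 likewise reaches only a limit, > 10000 nM. Both values sit at the limit of > 10000 nM in this assay, at which 2 of the 2 values shown sit, so compound 1 cannot be placed among real numbers: everything shown is a limit. Compound 3 differs from compound 1 by 3-hydroxyphenyl in place of 4-bromophenyl on a double-bonded chain carbon bound to a double-bonded chain carbon. Among the measured compounds shown here, with no measured step to compare, the step that the limit leaves unreadable from compound 1 to compound 3 is expected to stay within the usual scatter, in no clear direction. Compound 3 is therefore expected to give about 12000 nM, somewhere between 3000 nM and 50000 nM.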

Compound 3, half-maximal inhibitory concentration: > 10000 nM
Compound 3 ended at the assay's limit; the forecaster's own chance of this, stated with the estimate: 70%; the middle value is on the limit's open side.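

Compound 3 stops at a limit of the assay, > 10000 nM, as compound 1 does, so the change between these two compounds cannot be read: the limit of > 10000 nM in this assay, at which 3 of the 3 values shown sit.

The compounds shown leave open whether any change to this series gives a measurable value.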